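A few compounds are considered here, and "the series" means these few. Any claim that something is new, unique, unknown or untested is made for them only; others in the source may bear on it.

Compound 1 `NS(=O)(=O)c1ccc(Nc2nc(N/N=C/c3ccc(C(F)(F)F)cc3)nc(Nc3ccccc3)n2)cc1`: 2660 nM
Compound 2 `Cc1nn(-c2ccccc2)cc1/C=N/Nc1nc(Nc2ccccc2)nc(Nc2ccc(S(N)(=O)=O)cc2)n1`: 2660 nM

In a functional assay on NCI-H522 cells (Homo sapiens) for inhibition, read by sulforhodamine B assay, with a stated time of 48 h (on this read-out higher numbers stand for weaker inhibition of growth and lower numbers for stronger inhibition of growth), compound 1 gives 2660 nM and compound 2 gives 2660 nM. The one recorded step, no change at the digits printed from compound 1 to compound 2 (within the scatter), puts compound 2 level with compound 1 at the digits shown, so compound 2 stands at the same place as its only measured neighbour.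

Compound 3 `NS(=O)(=O)c1ccc(Nc2nc(N/N=C/c3ccccn3)nc(Nc3ccccc3)n2)cc1` differs from compound 2 in one place: pyridin-2-yl in place of 3-methyl-1-phenyl-1H-pyrazol-4-yl on a carbon with a double bond to nitrogen. Among the compounds with values here, the single measured step that bears on this position is the change of the group on the carbon with a double bond to nitrogen, no change at the digits printed from compound 1 to compound 2 (within the scatter), which stayed within the scatter. On that basis no step beyond the scatter is expected in this assay from compound 2 to compound 3, although the entering group is smaller than either group tried before, so the range is kept wide. Compound 3 is therefore estimated at 2660 nM, with a range from 900 nM to 8000 nM. The expected step is no change at the digits printed from compound 2 to compound 3 (within the scatter).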

Compound 3, concentration for 50% growth inhibition: 450 nM
Compound 3: the middle estimate sits 5.9-fold (0.77 log units) above what was measured; the measured number lies below the stated range.
By their numbers in this assay, from the lowest: compound 3; then compounds 1 and 2 (each within the scatter of the next).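

In this assay, the group on the carbon with a double bond to nitrogen does affect the read-out: the two earlier groups stood level, whereas pyridin-2-yl gives a 5.9-fold lower number from compound 2 to compound 3 (0.77 log units; beyond the scatter) and a 5.9-fold lower number from compound 1 to compound 3 (0.77 log units; beyond the scatter), both towards stronger inhibition of growth. The step from compound 2 replaces a group of 12 heavy atoms with one of 6, but with three compounds the smaller size cannot be separated from the change of ring. Nothing measured here accounts for the gain.

The compounds shown leave open whether the gain depends on the ring nitrogen and its location, which plain phenyl, pyridin-3-yl and pyridin-4-yl would test. They also do not show how a methoxy group or an amine on the pyridine ring would affect inhibition of growth.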